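Fluoro in place of chloro: what to expect

This account rests on a few compounds, and the source may have more. Where it says the series, first, only, none or still open, it means among the compounds named here.

Compound 1 `O=C(CCCCC(S)CCS)Nc1ccccc1` gives 8.62%
Compound 2 `O=C(CCCCC(S)CCS)Nc1ccc(Cl)cc1` gives 18.2%
Compound 3 `O=C(CCCCC(S)CCS)Nc1ccc(F)cc1` is not yet measured

In a functional assay on KB cells (Homo sapiens) for inhibition, read by MTT assay, with a stated time of 24 h, tested at 10 ug/mL (a higher number here means more inhibition of growth at the concentration tested, a lower number less inhibition of growth), compound 2 gives 18.2% and cannot be told apart from compound 1, which gives 8.62% in the same test. Compound 3 differs from compound 2 at a single spot: fluoro in place of chloro on an aromatic carbon. For the measured compounds named here, the only measured step that bears on this swap is a number 9.6 percentage points higher from compound 1 to compound 2 (within the scatter) for chloro in place of hydrogen on an aromatic carbon, and it stays within the scatter. Going by the values given here, no measurement yet shows what fluoro does here, so no step beyond the scatter is expected in this assay in either direction. The expected step is a number 4.2 percentage points lower from compound 2 to compound 3 (within the scatter) and it is only an estimate. The estimate for compound 3 is 14% with an expected range from 4% to 26% in this test.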

Compound 3, percent growth inhibition at one concentration: 13.3%
Beside the measured number, compound 3's estimate is 0.7 percentage points above it, within the range that was stated.
By their numbers in this assay, from the lowest: compounds 1, 3 and 2 (each within the scatter of the next).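

In this assay fluoro in place of chloro on this aromatic carbon gives a number 4.9 percentage points lower from compound 2 to compound 3 (within the scatter) and fluoro in place of hydrogen gives a number 4.7 percentage points higher from compound 1 to compound 3 (within the scatter) and both steps stay within the scatter. The earlier pair compared only chloro with hydrogen, whereas a second halogen now shows the same picture: with hydrogen, fluoro or chloro at this position, para to a large group, the three compounds cannot be told apart in this test. Nothing available explains how these groups act on the cells.

Going by these compounds, what an amine, a carboxylic acid or a methoxy group would do on this same carbon remains open. Also open, on these data alone, is whether any change at this position, or a longer chain elsewhere on the shared core, would move the number beyond the scatter.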